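A few compounds are considered here, and "the series" means these few. Any claim that something is new, unique, unknown or untested is made for them only; others in the source may bear on it.

Compound 1 `COc1cc(C(=O)c2sc3ccccc3c2-c2ccc(Cl)cc2)cc(OC)c1OC` with 5200 nM
Compound 2 `COc1cc(C(=O)c2sc3ccccc3c2-c2ccc(SC)cc2)cc(OC)c1OC` with 3500 nM
Compound 3 `COc1ccc(-c2c(C(=O)c3cc(OC)c(OC)c(OC)c3)sc3ccccc23)c(OC)c1` not yet measured

Both numbers come from a functional assay on HeLa cells (Homo sapiens) for antiproliferative activity, read by MTT assay, with a stated time of 72 h (on this read-out lower numbers stand for stronger inhibition and higher numbers for weaker inhibition), and they sit close together. Compound 2, at 3500 nM, lies within the scatter of compound 1, so neither stands apart from the other.

The change now in view is 2,4-dimethoxyphenyl in place of 4-(methylsulfanyl)phenyl on an aromatic carbon. Among the compounds with values here, no measured compound carries a methoxy group on this phenyl group, so the data offer no direct guide to what the new substitution does. Within the data shown here, the one measured step, a 1.5-fold lower number from compound 1 to compound 2 (0.17 log units; within the scatter), altered the same phenyl group, and on that slim evidence no shift beyond the scatter is expected in this assay for compound 3. The range must stay wide all the same, since a single small step is all there is to go on. The estimated step is a 1.1-fold higher number from compound 2 to compound 3 (0.06 log units; within the scatter) and no more than that is expected. For compound 3 the expected value is 4000 nM, with an estimated range from 1000 nM to 15000 nM in this assay.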

Compound 3, half-maximal inhibitory concentration: 3900 nM
For compound 3 the middle estimate is 1.0-fold (0.01 log units) above the measured one; low and high end bracket the measured number.
By their numbers in this assay, from the lowest: compounds 2, 3 and 1 (each within the scatter of the next).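

In this assay, 2,4-dimethoxyphenyl in place of 4-(methylsulfanyl)phenyl gives a 1.1-fold higher number from compound 2 to compound 3 (0.05 log units; within the scatter) and the same group in place of 4-chlorophenyl gives a 1.3-fold lower number from compound 1 to compound 3 (0.12 log units; within the scatter) so the entering group, which has no sulfur or chlorine and brings two oxygens, leaves the number within the scatter of both earlier compounds. Until now the position had been probed only with a single group on the phenyl ring, whereas compound 3 shows that a phenyl group with two methoxy groups and more heavy atoms also gives no separable difference, and across compounds 1, 2 and 3 this position has not yet produced a step beyond the scatter in this read-out. No measurement shown here accounts for this flat result or connects it to any property of these groups.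

The compounds shown leave open whether a basic amine or a carboxylic acid on this phenyl group would separate from these three numbers. They also leave open whether a hydroxy group on the ring, or a longer chain in place of the whole phenyl group, would do so.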